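Three Measured Analogues and One Expected Value

A few compounds are considered here, and "the series" means these few. Any claim that something is new, unique, unknown or untested is made for them only; others in the source may bear on it.

Measured so far:
Compound 1, `O=C(CSc1ccc([N+](=O)[O-])cc1)N1N=C(c2cc3ccccc3oc2=O)C[C@@H]1c1ccccc1C(F)(F)F`, gives 9770 nM in a functional assay on SGC-7901 cells (Homo sapiens) for cytotoxicity, read by MTT assay, with a stated time of 48 h; on this read-out higher numbers stand for weaker inhibition and lower numbers for stronger inhibition.
Compound 2, `O=C(CSCc1ccco1)N1N=C(c2cc3ccccc3oc2=O)C[C@@H]1c1ccccc1C(F)(F)F`, gives 10300 nM.
Compound 3, `O=C(CSCc1ccco1)N1N=C(c2cc3ccccc3oc2=O)C[C@@H]1c1ccc(C(F)(F)F)cc1`, gives 9740 nM.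

Compound 4, `O=C(CSc1ccc([N+](=O)[O-])cc1)N1N=C(c2cc3ccccc3oc2=O)C[C@@H]1c1ccc(C(F)(F)F)cc1`, has not yet been measured. It differs from compound 3 by 4-nitrophenyl in place of (furan-2-yl)methyl on a sulfur. The same change has already been made once, as 4-nitrophenyl in place of (furan-2-yl)methyl on a sulfur, and there it produced a 1.1-fold lower number from compound 2 to compound 1 (0.02 log units; within the scatter). Both occurrences sit at the same place, on a sulfur whose other neighbours are: saturated chain carbon, so the change is the same in both pairs. The cores on which it is made differ by 4-(trifluoromethyl)phenyl in place of 2-(trifluoromethyl)phenyl on a saturated ring carbon, a change that itself produced a 1.1-fold lower number from compound 2 to compound 3 (0.02 log units; within the scatter). All three measured numbers lie within the usual scatter of one another, so none of the three compounds can be called stronger or weaker than the others.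

The expected step from compound 3 to compound 4 in this assay is a 1.0-fold lower number from compound 3 to compound 4 (0.01 log units; within the scatter), resting on the earlier step of a 1.1-fold lower number from compound 2 to compound 1 (0.02 log units; within the scatter) made on the other core. Compound 4 is therefore estimated at 9500 nM, with an expected range from 5000 nM to 19000 nM.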

Compound 4, half-maximal inhibitory concentration: 8510 nM
The estimate for compound 4 lay 1.1-fold (0.05 log units) above the measured number; low and high end bracket the measured number.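

Putting 4-nitrophenyl in place of (furan-2-yl)methyl on the sulfur gives a 1.1-fold lower number from compound 3 to compound 4 (0.06 log units; within the scatter), and this step agrees with the one already seen on the other core: the same change on two cores in this assay, a 1.1-fold lower number (0.02 log units; within the scatter) from compound 2 to compound 1 and a 1.1-fold lower number (0.06 log units; within the scatter) from compound 3 to compound 4, 1.1-fold (0.04 log units) apart, within the scatter of two such steps. Likewise, 4-(trifluoromethyl)phenyl in place of 2-(trifluoromethyl)phenyl on a saturated ring carbon gives a 1.1-fold lower number from compound 1 to compound 4 (0.06 log units; within the scatter), which again agrees with its earlier counterpart: the same change on two cores in this assay, a 1.1-fold lower number (0.02 log units; within the scatter) from compound 2 to compound 3 and a 1.1-fold lower number (0.06 log units; within the scatter) from compound 1 to compound 4, 1.1-fold (0.04 log units) apart, within the scatter of two such steps. Within the data shown here, since every one of these steps lies within the scatter, the agreement shows only that neither change shifts the number measurably on these two cores in this assay; it does not show that a change with a real effect would carry from one core to another.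

The compounds shown leave open whether a group bearing an amine or a carboxylic acid on the sulfur would give a step beyond the scatter and, if so, whether that step would carry over. They also leave open what a nitrile in place of trifluoromethyl would do on the phenyl ring.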